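From compound 3 to compound 4: working notes

A few compounds are considered here, and "the series" means these few. Any claim that something is new, unique, unknown or untested is made for them only; others in the source may bear on it.

Measured in a functional assay on PC-3 cells (Homo sapiens) for antiproliferative activity, read by MTT assay, with a stated time of 72 h; a higher number here means a weaker inhibitor, a lower number a stronger inhibitor
- compound 1 `CCN(CC)CCCNC(=O)c1ccc(C(CC)(CC)c2ccc(C#CC(O)(CC)CC)c(C)c2)n1CC` gives 8500 nM
- compound 2 `C#CCCOC(=O)c1ccc(C(CC)(CC)c2ccc(C#CC(O)(CC)CC)c(C)c2)n1CC` gives > 50000 nM (a limit of the assay, not a number)
- compound 3 `CCn1c(C(=O)NCC(=O)O)ccc1C(CC)(CC)c1ccc(C#CC(O)(CC)CC)c(C)c1` gives 2250 nM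

Of the two actual numbers, compound 3 holds the lower, with compound 1 the nearest value. Compound 2 reports only a limit.

Compound 4 `CCn1c(C(=O)NCCC(=O)O)ccc1C(CC)(CC)c1ccc(C#CC(O)(CC)CC)c(C)c1` differs from compound 3 by carboxymethyl in place of carboxy on a saturated chain carbon bound to an amide-type nitrogen with carboxymethyl in place of carboxy on a saturated chain carbon bound to an amide-type nitrogen, so that (2-carboxyethyl)carbamoyl replaces (carboxymethyl)carbamoyl.

Among the measured compounds shown here, two measured steps bear on this: the modest 3.8-fold lower number from compound 1 to compound 3 (0.58 log units; beyond the scatter) and the large at least 22-fold lower number from compound 2 to compound 3 (1.34 log units; beyond the scatter) in the same region. Both exchange one kind of group for another, and neither lengthens a chain that keeps its carboxy. Compound 4 retains that carboxy, so its expected number stays close to that of compound 3 (2250 nM) and neither measured step sets its size. The step expected in this assay is small, slightly upward and not beyond the scatter: a 1.3-fold higher number from compound 3 to compound 4 (0.12 log units; within the scatter) as estimated.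

Compound 4 is estimated at 3000 nM (range 1000 nM to 9000 nM).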

Compound 4, half-maximal inhibitory concentration: 5130 nM
Compound 4: middle estimate off by 1.7-fold (0.23 log units), on the low side; measured number inside the range.
By their numbers in this assay, from the lowest: compound 3; then compounds 4 and 1 (each within the scatter of the next). At a limit, above all of these: compound 2.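

In this assay, the carboxy is kept and only the chain grows from carboxymethyl to 2-carboxyethyl, yet the position still responds: a 2.3-fold higher number from compound 3 to compound 4 (0.36 log units; beyond the scatter). The earlier steps shown here exchanged one kind of group for another, whereas this one shows that chain length alone matters here, and the advantage of compound 3 does not carry over to the longer acid, with a 1.7-fold lower number from compound 1 to compound 4 (0.22 log units; within the scatter) leaving compound 1 and compound 4 unseparated. Compound 2 gives only a limit, so an at least 9.7-fold lower number from compound 2 to compound 4 (0.98 log units; beyond the scatter) is a bound and not a size: the limit of > 50000 nM in this assay, at which 1 of the 4 values shown sits.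

Among the compounds shown here, with only two chain lengths carrying the carboxy, no trend can be drawn, and a longer chain such as 3-carboxypropyl remains open. Also open, as far as these compounds go, is whether a methyl ester or a primary amide in place of the carboxy would hold the value of compound 3.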